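The compounds below may be only part of what the source reports. "The series", "measured", "known", "first", "only" and "open" are said of these compounds alone.

Measured so far:
Compound 1 `CO/C(O)=C1\C(C)=NC(C)=C(C(=O)OCC(C)C)C1c1ccccc1C(F)(F)F` gives 2.1 nM
Compound 2 `CO/C(O)=C1\C(C)=NC(C)=C(C(=O)OCC(C)C)C1c1ccc(F)cc1` gives 6.8 nM

Both compounds were tested in a functional assay (muscle tissue) for inhibition, with Cavia porcellus as the target; a higher number here means a weaker inhibitor, a lower number a stronger inhibitor. On these two numbers compound 2 stands at the higher one; compound 1 sits lower, and the gap between the two values is wider than the usual scatter of repeated measurements, so the two compounds genuinely differ in this assay. Going by the values given here, no single-point step between them has been worked out, since they differ in more than one place on the aryl group.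

Compound 3 `CO/C(O)=C1\C(C)=NC(C)=C(C(=O)OCC(C)C)C1c1cccc(OC)c1` has not yet been measured. It differs from compound 2 in one place: 3-methoxyphenyl in place of 4-fluorophenyl on a saturated ring carbon. Among the compounds with values here, no measured step shows what such a swap does here, so only a cautious expectation is possible: a modest shift in this assay, of the size a 1.4-fold lower number from compound 2 to compound 3 (0.13 log units; within the scatter), is expected, and it could fall either way. Compound 3 is therefore estimated at 5 nM, with a likely range from 1.5 nM to 20 nM.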

Compound 3, half-maximal inhibitory concentration: 7.1 nM
Compound 3: middle estimate off by 1.4-fold (0.15 log units), on the low side; measured number inside the range.
By their numbers in this assay, from the lowest: compound 1; then compounds 2 and 3 (each within the scatter of the next).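

In this assay, putting 3-methoxyphenyl in place of 4-fluorophenyl on the saturated ring carbon gives a 1.0-fold higher number from compound 2 to compound 3 (0.02 log units; within the scatter), so this swap produces no readable change. The position therefore accepts these two different aryl groups with the same result, even though 3-methoxyphenyl has a hydrogen-bond acceptor and 4-fluorophenyl has none. Going by these compounds alone, this is the first one-place comparison, but it covers only this single pair of groups.

As far as these compounds go, it remains open whether the same holds for a phenyl ring carrying an amine, a carboxylic acid or a longer chain such as butoxy in place of methoxy. Why compound 2 and compound 3 match also stays open, as no supporting measurement on this point is available.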